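The source may report more compounds than this note shows. Statements on the series, on what has been measured and on what is new or still open speak of the compounds shown alone.

Compound 3 `O=C(Oc1ccc([N+](=O)[O-])cc1)N1CCN(S(=O)(=O)c2ccc(Oc3ncc(C(F)(F)F)cc3Cl)cc2)CC1` gives the highest number of the three measured in an assay on isolated protein for inhibition of Fatty-acid amide hydrolase 1 (Homo sapiens), read by fluorescence (a higher number here means a weaker inhibitor, a lower number a stronger inhibitor), at 2950 nM; compound 1 `O=C(Oc1ccc([N+](=O)[O-])cc1)N1CCN(S(=O)(=O)c2ccc(Oc3ccc(Cl)c(Cl)c3)cc2)CC1` gives 317 nM and compound 2 `O=C(Oc1ccc([N+](=O)[O-])cc1)N1CCN(S(=O)(=O)c2ccc(Oc3ccc(Cl)cc3)cc2)CC1` gives 153 nM. Compound 4 `O=C(Oc1ccc([N+](=O)[O-])cc1)N1CCN(S(=O)(=O)c2ccc(Oc3ccccc3Cl)cc2)CC1` differs from compound 3 by 2-chlorophenyl in place of 3-chloro-5-(trifluoromethyl)pyridin-2-yl on an oxygen on an aromatic ring. For the measured compounds named here, two measured steps bear on this change, both running the other way: a 9.3-fold higher number from compound 1 to compound 3 (0.97 log units; beyond the scatter) and a 19-fold higher number from compound 2 to compound 3 (1.29 log units; beyond the scatter). Going by the values given here, both chlorophenyl compounds thus sit well below compound 3, and the ring entering in compound 4 is again a chlorophenyl, so a lower number beyond the scatter is expected, of a size near those two steps, although the single chloro of compound 4 has no measured counterpart among the three. For compound 4 the expected step is an 11-fold lower number from compound 3 to compound 4 (1.02 log units; beyond the scatter). Compound 4 is estimated at 280 nM, within 100 nM to 800 nM.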

Compound 4, half-maximal inhibitory concentration: 1150 nM
Beside the measured number, compound 4's estimate is 4.1-fold (0.61 log units) below it; measured number outside the range, above it.
By their numbers in this assay, from the lowest: compound 2; then compound 1; then compound 4; then compound 3.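

Putting 2-chlorophenyl in place of 3-chloro-5-(trifluoromethyl)pyridin-2-yl closes only part of the gap to the other chlorophenyl compounds (a 2.6-fold lower number from compound 3 to compound 4 (0.41 log units; beyond the scatter)), and compound 4 stays weaker than both (a 7.5-fold higher number from compound 2 to compound 4 (0.88 log units; beyond the scatter); a 3.6-fold higher number from compound 1 to compound 4 (0.56 log units; beyond the scatter)). On this oxygen, then, a chlorophenyl ring alone does not fix the number: 2-chlorophenyl and 4-chlorophenyl differ beyond the scatter. Nothing available explains these differences. As far as these compounds go, how an unsubstituted phenyl, or a phenyl carrying a methoxy group or an amine, would rank here remains open.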